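Thiophen-2-yl in place of 4-cyanophenyl on the shared core

The source may report more compounds than this note shows. Statements on the series, on what has been measured and on what is new or still open speak of the compounds shown alone.

In a functional assay on DU-145 cells (Homo sapiens) for inhibition, read by MTT assay, with a stated time of 48 h (on this read-out lower numbers stand for stronger inhibition and higher numbers for weaker inhibition), compound 1 `CSc1ccc(-c2nc3ccccn3c2Sc2ccccc2)cc1` gives 52100 nM, and compound 2 `N#Cc1ccc(-c2nc3ccccn3c2Sc2ccccc2)cc1` gives 76500 nM. Only these two numbers are available, and compound 2 stands level with compound 1: a 1.5-fold higher number from compound 1 to compound 2 (0.17 log units; within the scatter). That step, cyano in place of methylsulfanyl, keeps the aromatic ring and alters only the group it carries.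

Compound 3 `c1ccc(Sc2c(-c3cccs3)nc3ccccn23)cc1` has not been measured. Relative to compound 2, the change is thiophen-2-yl in place of 4-cyanophenyl on an aromatic carbon. Here thiophen-2-yl takes the place of the whole 4-cyanophenyl on an aromatic carbon, so the ring itself leaves. Going by the values given here, no measured compound shows such a replacement, and the step between compound 1 and compound 2 bears on it only loosely. That single step gives no direction, so no shift beyond the scatter is expected in this assay, although the uncertainty is wide. The number of compound 2, 76500 nM, serves as the anchor, with a slight allowance towards compound 1 at 52100 nM.

The expected step is a 1.3-fold lower number from compound 2 to compound 3 (0.11 log units; within the scatter).

Compound 3 is estimated at 60000 nM, with an expected range of 25000 nM to 130000 nM.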

Compound 3, half-maximal inhibitory concentration: 24100 nM
Beside the measured number, compound 3's estimate is 2.5-fold (0.40 log units) above it, and the stated range ends above it.
By their numbers in this assay, from the lowest: compound 3; then compounds 1 and 2 (each within the scatter of the next).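

In this assay, exchanging the whole ring on this aromatic carbon moves the number beyond the scatter, which changing only the group carried by the phenyl ring did not do (a 1.5-fold higher number from compound 1 to compound 2 (0.17 log units; within the scatter)). Thiophen-2-yl in place of 4-cyanophenyl gives a 3.2-fold lower number from compound 2 to compound 3 (0.50 log units; beyond the scatter), and thiophen-2-yl in place of 4-(methylsulfanyl)phenyl gives a 2.2-fold lower number from compound 1 to compound 3 (0.33 log units; beyond the scatter), so both modest steps run in the same direction and compound 3 has the lowest number of the three. Nothing in the available data accounts for this shift.

Going by these compounds alone, with only one five-membered ring in the set, it remains open whether the lower number belongs to thiophen-2-yl itself or simply to the loss of the substituted phenyl ring; an unsubstituted phenyl, furan-2-yl or pyridinyl group on the same carbon would separate these readings. As far as these compounds go, the phenylsulfanyl group is common to all three compounds, so it also remains open how the number would respond to an amine or a longer alkyl chain in its place.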